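The compounds below may be only part of what the source reports. "The series", "measured", "known", "first", "only" and "open" are said of these compounds alone.

Of the compounds shown here, three sharing one core have been read in a functional assay on MCF7 cells (Homo sapiens) for inhibition, read by MTT assay, with a stated time of 48 h, tested at 10 uM (on this read-out higher numbers stand for more inhibition of growth at the one concentration tested and lower numbers for less inhibition of growth), and they differ only in the amine on a saturated chain carbon bound to an aromatic carbon. The diethylamino member, compound 1 (`CCN(CC)Cc1c(O)c([C@H]2CCN(C)C[C@H]2O)c2oc(C)cc(=O)c2c1O`), gives 24% in this test. The 4-(ethoxycarbonyl)piperazin-1-yl member, compound 2 (`CCOC(=O)N1CCN(Cc2c(O)c([C@H]3CCN(C)C[C@H]3O)c3oc(C)cc(=O)c3c2O)CC1`), gives 31% in the same test. The diisopropylamino member, compound 3 (`Cc1cc(=O)c2c(O)c(CN(C(C)C)C(C)C)c(O)c([C@H]3CCN(C)C[C@H]3O)c2o1`), gives 33% and cannot be told apart from the other two. The steps bear this out: a number 7 percentage points higher from compound 1 to compound 2 (within the scatter), a number 9 percentage points higher from compound 1 to compound 3 (within the scatter) and a number 2 percentage points higher from compound 2 to compound 3 (within the scatter).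

Compound 4 (`Cc1cc(=O)c2c(O)c(CN3CC(O)CC3C(=O)O)c(O)c([C@H]3CCN(C)C[C@H]3O)c2o1`) carries 2-carboxy-4-hydroxypyrrolidin-1-yl in place of diisopropylamino at that same place (2-carboxy-4-hydroxypyrrolidin-1-yl in place of diisopropylamino on a saturated chain carbon bound to an aromatic carbon). All three measured exchanges bear on this change, since they occurred at the same place, but none of those compounds carries the entering group, so they guide it only indirectly. Since none of those exchanges left the scatter, no step beyond the scatter is expected in this assay, and no direction can be firmly expected. The estimated change is a number 6 percentage points lower from compound 3 to compound 4 (within the scatter) and remains uncertain. Compound 4 is therefore expected at 27% (estimated range 10% to 42%).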

Compound 4, percent growth inhibition at one concentration: 25%
The estimate for compound 4 lay 2 percentage points above the measured number; the range from low to high includes it.
By their numbers in this assay, from the lowest: compounds 1, 4, 2 and 3 (each within the scatter of the next).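

Putting 2-carboxy-4-hydroxypyrrolidin-1-yl in place of diisopropylamino on a saturated chain carbon bound to an aromatic carbon brings in a five-membered non-aromatic ring, more hydrogen-bond donors and acceptors and three oxygens, yet this assay gives only a number 8 percentage points lower from compound 3 to compound 4 (within the scatter) for this exchange. The entering group also stays close to the two remaining amines, with a number 6 percentage points lower from compound 2 to compound 4 (within the scatter) and a number 1 percentage points higher from compound 1 to compound 4 (within the scatter), so this much larger structural change at the same place still separates none of the four compounds shown, and the earlier open-chain and piperazine amines had not tested a ring carrying a carboxylic acid and a hydroxy group. No evidence on the cause of this flat reading is available.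

From the compounds shown here alone, whether 2-carboxypyrrolidin-1-yl, with the carboxylic acid but without the hydroxy group, or a plain 4-hydroxypiperidin-1-yl would read the same remains open, as does the effect of a longer chain between the amine and the aromatic carbon. With one concentration and a shared core throughout, the compounds also leave open whether any of these amines would separate from the others at a higher concentration.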